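Halogen Substitution on the Pendant Aryl Ring

This account rests on a few compounds, and the source may have more. Where it says the series, first, only, none or still open, it means among the compounds named here.

Compound 3 `CCCNC(=O)c1cc(Oc2ccc(NC(=O)c3cc4cccnc4n(-c4ccc(Cl)cc4)c3=O)cc2)ccn1` gives 390 nM in a functional assay on HT-29 cells (Homo sapiens) for antiproliferative activity, read by MTT assay, with a stated time of 72 h (on this read-out lower numbers stand for stronger inhibition and higher numbers for weaker inhibition), the second highest of the three numbers shown. Compound 2 `CCCNC(=O)c1cc(Oc2ccc(NC(=O)c3cc4cccnc4n(-c4ccccc4)c3=O)cc2)ccn1` gives 98 nM in this assay, and compound 1 `CNC(=O)c1cc(Oc2ccc(NC(=O)c3cc4cccnc4n(-c4ccc(Br)cc4F)c3=O)cc2)ccn1` gives 1950 nM. Within the data shown here, the step of a 4.0-fold higher number from compound 2 to compound 3 (0.60 log units; beyond the scatter) is the only single-change step among the measured compounds. Compound 4 `CCCNC(=O)c1cc(Oc2ccc(NC(=O)c3cc4cccnc4n(-c4ccc(Br)cc4F)c3=O)cc2)ccn1` differs from compound 3 by 4-bromo-2-fluorophenyl in place of 4-chlorophenyl on an aromatic nitrogen. Among the measured compounds shown here, no measured step isolates this exact change, but compound 1 carries the same 4-bromo-2-fluorophenyl group and shows the highest number of the three, which points toward weaker inhibition. Compound 4 is therefore expected to give a higher number than compound 3, with an expected step of a 2.1-fold higher number from compound 3 to compound 4 (0.31 log units; beyond the scatter). The estimate for compound 4 is 800 nM, with a range from 250 nM to 2500 nM.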

Compound 4, half-maximal inhibitory concentration: 2160 nM
For compound 4 the middle estimate is 2.7-fold (0.43 log units) below the measured one; low and high end bracket the measured number.
By their numbers in this assay, from the lowest: compound 2; then compound 3; then compounds 1 and 4 (each within the scatter of the next).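

In this assay, 4-bromo-2-fluorophenyl in place of 4-chlorophenyl on the aromatic nitrogen gives a 5.5-fold higher number from compound 3 to compound 4 (0.74 log units; beyond the scatter) and thus extends the loss seen with chloro, while the same group in place of phenyl gives a 22-fold higher number from compound 2 to compound 4 (1.34 log units; beyond the scatter) as the largest step at this position. With this aryl group in both compounds, ethyl in place of hydrogen on the chain gives a 1.1-fold higher number from compound 1 to compound 4 (0.04 log units; within the scatter) and so separates neither compound from the other. The data offer no evidence on the cause of these steps. The compounds shown do not separate the bromine from the fluorine, as neither 4-bromophenyl nor 2-fluorophenyl is among them. From the compounds shown here alone, how a methoxy group or an amine on this ring would read also remains open.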